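The source may report more compounds than this note shows. Statements on the series, on what has been measured and on what is new or still open speak of the compounds shown alone.

Of the compounds shown here, two have so far been measured in a functional assay on MCF7 cells (Homo sapiens) for antiproliferative activity, read by MTT assay, with a stated time of 72 h; on this read-out lower numbers stand for stronger inhibition and higher numbers for weaker inhibition. Compound 1, `CCN1CCN(c2cc(C)c3cc(NC(=O)c4ccccc4F)ccc3n2)CC1`, gives 32600 nM in this assay. Compound 2, `Cc1cc(NCCN(C)C)nc2ccc(NC(=O)c3ccc(Cl)c(Cl)c3)cc12`, gives 2550 nM in this assay, the lower of the two numbers, and its gap to compound 1 lies beyond the scatter, so compound 2 stands as the stronger of the pair on the evidence available.

Compound 3, `Cc1cc(NCCN2CCN(C)CC2)nc2ccc(NC(=O)c3ccc(Cl)c(Cl)c3)cc12`, has not yet been measured in this assay. It differs from compound 2 in a single place: 4-methylpiperazin-1-yl in place of dimethylamino on a saturated chain carbon, two bonds along the chain from a nitrogen on an aromatic ring. Among the compounds with values here, no measured pair of compounds shows this change on its own, so nothing in the data fixes its size or its direction. With the rest of the structure unchanged, the move from compound 2 to compound 3 is expected to be modest, quite possibly within the scatter, and its direction is left open. The expected step of a 1.0-fold lower number from compound 2 to compound 3 (0.01 log units; within the scatter) reflects that view. Compound 3 is estimated to give about 2500 nM in this assay, with a range from 800 nM to 8000 nM.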

Compound 3, half-maximal inhibitory concentration: 1700 nM
Compound 3: middle estimate off by 1.5-fold (0.17 log units), on the high side; low and high end bracket the measured number.
By their numbers in this assay, from the lowest: compounds 3 and 2 (each within the scatter of the next); then compound 1.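

In this assay, replacing dimethylamino with 4-methylpiperazin-1-yl on a saturated chain carbon, two bonds along the chain from a nitrogen on an aromatic ring, now has a measured size: a 1.5-fold lower number from compound 2 to compound 3 (0.18 log units; within the scatter). This position therefore accepts a group of 7 heavy atoms with a six-membered non-aromatic ring in place of one of 3 heavy atoms with no ring, with no step beyond the scatter, something the earlier pair could not show, as compound 1 and compound 2 differ in more than one place. Nothing available gives a reason for this outcome.

The compounds shown leave open whether other groups at this place, such as a morpholine ring, a primary amine or a carboxylic acid, would also stay within the scatter of compound 2, and whether a longer chain would do the same. Within the data shown here, they also leave open whether this step would hold with another amide part, such as the one carried by compound 1.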